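The source may hold more compounds than are shown below. What is called first, only, known or untested is meant among the compounds shown, and "the series" means these compounds.

Measured in a functional assay on PC-3 cells (Homo sapiens); a higher number here means a weaker inhibitor of growth, a lower number a stronger inhibitor of growth:
- compound 1 `O=S(=O)(/C=C/c1ccc(Cl)c(Cl)c1)Cc1ccc(Nc2ncnc3ccccc23)cc1`: 35000 nM
- compound 2 `O=S(=O)(/C=C/c1ccc(Br)cc1)Cc1ccc(Nc2ncnc3ccccc23)cc1`: 42000 nM
- compound 3 `O=S(=O)(/C=C/c1ccc(Br)cc1)Cc1ccc(Nc2ncnc3ccc(Br)cc23)cc1`: 34000 nM

The three values lie within the scatter of one another, so compound 3, at 34000 nM, is not set apart from the other two. Compound 4 `O=S(=O)(/C=C/c1ccc(C(F)(F)F)cc1F)Cc1ccc(Nc2ncnc3ccc(Br)cc23)cc1` departs from compound 3 in one place: 2-fluoro-4-(trifluoromethyl)phenyl in place of 4-bromophenyl on a double-bonded chain carbon bound to a double-bonded chain carbon. Among the compounds with values here, the closest precedent is a change of aryl group at that same place, a 1.2-fold higher number from compound 1 to compound 2 (0.08 log units; within the scatter), which stayed within the scatter. The bromo change elsewhere, a 1.2-fold lower number from compound 2 to compound 3 (0.09 log units; within the scatter), also stayed within it. Neither step tests the entering group itself. In this assay the expected step is a 1.1-fold lower number from compound 3 to compound 4 (0.03 log units; within the scatter), none beyond the scatter. Compound 4 is estimated at 32000 nM, with an expected range from 15000 nM to 65000 nM.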

Compound 4, concentration for 50% growth inhibition: 58000 nM
Beside the measured number, compound 4's estimate is 1.8-fold (0.26 log units) below it; the range from low to high includes it.
By their numbers in this assay, from the lowest: compounds 3, 1, 2 and 4 (each within the scatter of the next).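

In this assay, 2-fluoro-4-(trifluoromethyl)phenyl in place of 4-bromophenyl (a 1.7-fold higher number from compound 3 to compound 4 (0.23 log units; within the scatter)) stays within the scatter. This shows that a ring carrying fluorine and trifluoromethyl, with more heavy atoms than the 4-bromophenyl it replaces, is tolerated at this place as the earlier aryl change was, here on the bromo-bearing core of compound 3. No measurement shown offers an explanation for this result. The compounds shown leave open whether an aryl ring bearing an amine or a carboxylic acid at this place would move the number beyond the scatter.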